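Trading the Bromoethyl Group for a Methylethenyl Group

The source may report more compounds than this note shows. Statements on the series, on what has been measured and on what is new or still open speak of the compounds shown alone.

Three compounds share one amide core and differ mainly in the group attached to the carbonyl carbon. Compound 1 `CCCCC(=O)N(Cc1ccc(OC)c(O)c1)c1cc(OC)c(OC)c(OC)c1` gives 300 nM in a functional assay on KYSE-450 cells (Homo sapiens) for inhibition, read by MTT assay, with a stated time of 48 h; on this read-out lower numbers stand for stronger inhibition and higher numbers for weaker inhibition. Compound 2 `COc1ccc(CN(C(=O)C(C)Br)c2cc(OC)c(OC)c(OC)c2)cc1O` gives 160 nM, and compound 3 `C/C=C/C(=O)N(Cc1ccc(OC)c(N)c1)c1cc(OC)c(OC)c(OC)c1`, which also carries an amino group in place of the hydroxy group, gives 310 nM. Compound 2 has the lowest of the three numbers, yet its gaps to compound 1 and to compound 3 both stay within the scatter, so no order among them can be claimed.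

Compound 4 `C=C(C)C(=O)N(Cc1ccc(OC)c(O)c1)c1cc(OC)c(OC)c(OC)c1` is the next step from compound 2: 1-methylethenyl in place of 1-bromoethyl on a carbonyl carbon. Going by the values given here, the one measured step that bears on it is the earlier swap at the same carbonyl carbon, a 1.9-fold lower number from compound 1 to compound 2 (0.27 log units; within the scatter), which was within the scatter. On that basis the new swap is expected to move the number by no more than the scatter, with no clear direction.

Compound 4 is therefore estimated at 200 nM, with a range from 90 nM to 450 nM, meaning a step of a 1.3-fold higher number from compound 2 to compound 4 (0.10 log units; within the scatter) is expected.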

Compound 4, half-maximal inhibitory concentration: 200 nM
Compound 4: the middle estimate sits on the measured number at the digits printed, within the range that was stated.
By their numbers in this assay, from the lowest: compounds 2, 4, 1 and 3 (each within the scatter of the next).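

In this assay, putting 1-methylethenyl in place of 1-bromoethyl on a carbonyl carbon gives a 1.3-fold higher number from compound 2 to compound 4 (0.10 log units; within the scatter) and putting it in place of butyl gives a 1.5-fold lower number from compound 1 to compound 4 (0.18 log units; within the scatter). The same position has now carried three different groups on an otherwise identical structure, and a group with a double bond and no bromine still gives no step beyond the scatter from either of the other two. Nothing measured here speaks to what lies behind these small steps.

Going by these compounds, whether a group of another kind at this carbonyl carbon, such as an amine, a carboxylic acid or a longer chain, would give a step beyond the scatter remains open. The amino group of compound 3 comes with a different group on the carbonyl carbon, so its contribution alone cannot be read.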